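A Pyrrole Replaces the Dihydroxyphenyl Group

This account rests on a few compounds, and the source may have more. Where it says the series, first, only, none or still open, it means among the compounds named here.

In a functional assay on HepG2 cells (Homo sapiens) for antiproliferative activity, read by MTT assay, with a stated time of 72 h (a lower number here means a stronger inhibitor, a higher number a weaker inhibitor), compound 1 (`O=C(N/N=C/c1cccc(Br)c1)Nc1ccc(Oc2ccnc3[nH]ccc23)c(F)c1`) gives 660 nM and compound 2 (`O=C(N/N=C/c1ccc(O)cc1O)Nc1ccc(Oc2ccnc3[nH]ccc23)c(F)c1`) gives 4550 nM as the higher of the two numbers. Compound 3 (`CN(C)CCn1cccc1/C=N/NC(=O)Nc1ccc(Oc2ccnc3[nH]ccc23)c(F)c1`) carries 1-(2-(dimethylamino)ethyl)-1H-pyrrol-2-yl in place of 2,4-dihydroxyphenyl on a carbon with a double bond to nitrogen. For the measured compounds named here, the only measured step at this place is a 6.9-fold higher number from compound 1 to compound 2 (0.84 log units; beyond the scatter) and it is modest but beyond the scatter. That single step is a thin guide, yet a modest move toward a lower number is expected in this assay (a 3.0-fold lower number from compound 2 to compound 3 (0.48 log units; beyond the scatter)). Compound 3 is estimated at 1500 nM (expected range 300 nM to 6000 nM).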

Compound 3, half-maximal inhibitory concentration: 8980 nM
Compound 3: the middle estimate sits 6.0-fold (0.78 log units) below what was measured; measured number outside the range, above it.
By their numbers in this assay, from the lowest: compound 1; then compounds 2 and 3 (each within the scatter of the next).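

Replacing 2,4-dihydroxyphenyl with 1-(2-(dimethylamino)ethyl)-1H-pyrrol-2-yl gives a 2.0-fold higher number from compound 2 to compound 3 (0.30 log units; within the scatter) in this assay, so these two quite different groups cannot be told apart in this assay. Measured against 3-bromophenyl, the same group gives a 14-fold higher number from compound 1 to compound 3 (1.13 log units; beyond the scatter), which leaves compound 1 with the lowest number of the three, clearly separated from both others. Nothing available explains these differences. From the compounds shown here alone, it remains open what a plain 1H-pyrrol-2-yl ring without the chain would give, and whether the pyrrole ring or its chain matters more. A 3-chlorophenyl group at this position is also an open case.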